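Swapping an amine-bearing ring for a fluorinated one

A few compounds are considered here, and "the series" means these few. Any claim that something is new, unique, unknown or untested is made for them only; others in the source may bear on it.

Compound 1 `CC(C)CN(c1ccc(N(C)C)cc1)S(=O)(=O)c1ccc2c(c1)C(O)CC(C1CCOCC1)O2` was measured in a physicochemical assay for lipophilicity, at pH 7.4 (a higher number here means a more lipophilic compound, a lower number a more polar compound), and gives 3.51. Going by the values given here, compound 2 `CCc1ccc(N(CC(C)C)S(=O)(=O)c2ccc3c(c2)CCC3OC2CCOCC2)cc1` is the only other measured compound and gives 4.96 in this assay, so compound 1 holds the lower of the two numbers, with a gap to compound 2 that is beyond the scatter. Among the compounds with values here, the two differ in several places at once, so no single step between them is known.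

Compound 3 `CC(C)CN(c1ccccc1C(F)(F)F)S(=O)(=O)c1ccc2c(c1)C(O)CC(C1CCOCC1)O2` is not yet measured. Its structure follows from compound 1 by one change: 2-(trifluoromethyl)phenyl in place of 4-(dimethylamino)phenyl on a sulfonamide nitrogen. The group that leaves carries one hydrogen-bond acceptor; the group that enters carries none and brings three fluorine atoms. From compound 1 a moderate rise in this assay is expected, beyond the scatter, giving an estimated step of a number 0.69 log units higher from compound 1 to compound 3 (beyond the scatter). For compound 3 the expected value is 4.2, within a range from 3.8 to 4.6.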

Compound 3, distribution coefficient: 4.14
Estimate against measurement, compound 3: 0.06 log units above; the range from low to high includes it.
By their numbers in this assay, from the lowest: compound 1; then compound 3; then compound 2.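

In this assay, going by these compounds alone, the swap of 4-(dimethylamino)phenyl for 2-(trifluoromethyl)phenyl on the sulfonamide nitrogen gives a number 0.63 log units higher from compound 1 to compound 3 (beyond the scatter), the first change in this set made in one place only. With the rest of compound 1 held fixed, the group on this nitrogen alone is enough to move the number by more than the usual scatter, which the comparison of compound 1 with compound 2 could not show, since those two differ in several places at once. No measurement shown explains why the number moves with this swap.

The step also changes two things together, the substituent and its place on the ring, and a single pair of compounds cannot separate them. A plain phenyl on the same nitrogen would show how much of the step comes from removing the dimethylamino group and how much from adding the trifluoromethyl group.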